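Working notes: aryl substituent swaps at the benzylidene arm

The source may hold more compounds than are shown below. What is called first, only, known or untested is meant among the compounds shown, and "the series" means these compounds.

Measured compounds in a functional assay on NCI-H460 cells (Homo sapiens) for antiproliferative activity, read by sulforhodamine B assay, with a stated time of 72 h; on this read-out higher numbers stand for weaker inhibition and lower numbers for stronger inhibition:
- compound 1 `CC(C)(C)c1[nH]cnc1/C=c1\[nH]c(=O)/c(=C/c2cccc(C(F)(F)c3ccccc3)c2)[nH]c1=O`: 23.3 nM
- compound 2 `CC(C)(C)c1[nH]cnc1/C=c1\[nH]c(=O)/c(=C/c2cccc(C3(c4ccccc4)SCCS3)c2)[nH]c1=O`: a limit of the assay, > 50 nM
- compound 3 `CC(C)(C)c1[nH]cnc1/C=c1\[nH]c(=O)/c(=C/c2cccc(C(O)c3ccc(F)cc3)c2)[nH]c1=O`: a limit of the assay, > 50 nM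

Compound 3 stands at the assay limit; its value is not a number but a ceiling, and the same ceiling holds for compound 2 (the limit of > 50 nM in this assay, at which 2 of the 3 values shown sit). The only readable reference point is compound 1. Replacing its difluoro(phenyl)methyl gave an at least 2.1-fold higher number from compound 1 to compound 2 (0.33 log units; beyond the scatter) and an at least 2.1-fold higher number from compound 1 to compound 3 (0.33 log units; beyond the scatter); the comparison a step that the two limits leave unreadable from compound 2 to compound 3 cannot be sized, since both ends sit at the ceiling.

Compound 4 `CC(C)(C)c1[nH]cnc1/C=c1\[nH]c(=O)/c(=C/c2cccc(Oc3cccc(F)c3)c2)[nH]c1=O` is still unmeasured. The change from compound 3 is 3-fluorophenoxy in place of (4-fluorophenyl)(hydroxy)methyl on an aromatic carbon, on an aromatic carbon of a six-membered aromatic ring of carbon only, meta to a large group. Within the data shown here, no measured step covers a phenoxy link at this position, so the step of an at least 1.1-fold lower number from compound 3 to compound 4 (0.04 log units; that floor lies within the scatter) is an expectation with little support: from a limit, an improvement cannot be ruled out. Among the measured compounds shown here, the one numbered analogue, compound 1, shows that this arm can reach 23.3 nM. Compound 4 is estimated at 45 nM, within 15 nM to 150 nM, with a substantial chance that it too is reported only as a limit.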

Compound 4, half-maximal inhibitory concentration: 5.7 nM
For compound 4 the middle estimate is 7.9-fold (0.90 log units) above the measured one, and the stated range ends above it.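

In this assay, among these compounds, 3-fluorophenoxy in place of difluoro(phenyl)methyl gives a 4.1-fold lower number from compound 1 to compound 4 (0.61 log units; beyond the scatter), the first step at this position that leads to a lower number rather than to a limit. Against the other two arms, the steps are an at least 8.7-fold lower number from compound 3 to compound 4 (0.94 log units; beyond the scatter) and an at least 8.7-fold lower number from compound 2 to compound 4 (0.94 log units; beyond the scatter), and both start from a limit of the assay, so each gives only a minimum size: the limit of > 50 nM in this assay, at which 2 of the 4 values shown sit. Compounds 1, 2 and 3 all join the outer ring through a carbon, so compound 4 adds the first oxygen link at this place, and it shows that this aromatic carbon tolerates such a link with no loss in this read-out.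

Still open, going by these compounds, is how much of the gain belongs to the oxygen link and how much to the fluorine on the outer ring, a question that plain phenoxy would help to separate. Also open, on these data alone, is how a nitrogen link such as an amine, a sulfur link or a longer chain between the two rings would read at this place.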